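Methylsulfanyl for methyl on a nucleoside core

The source may hold more compounds than are shown below. What is called first, only, known or untested is meant among the compounds shown, and "the series" means these compounds.

Measured so far:
Compound 1 `C#Cc1cn([C@@H]2O[C@H](CO)[C@@H](O)[C@H]2O)c2ncnc(C)c12`: > 20000 nM
Compound 2 `Cc1ncnc2c1c(-c1ccoc1)cn2[C@@H]1O[C@H](CO)[C@@H](O)[C@H]1O`: > 20000 nM
Compound 3 `Cc1ncnc2c1c(-c1cccs1)cn2[C@@H]1O[C@H](CO)[C@@H](O)[C@H]1O`: > 20000 nM

The reading is a functional assay on HCT-116 cells (Homo sapiens), read by MTT assay, with a stated time of 72 h; a higher number here means a weaker inhibitor, a lower number a stronger inhibitor. For compound 1 the value > 20000 nM is a limit of the assay, not a number. For compound 2 the value > 20000 nM is likewise a limit. For compound 3 the value > 20000 nM is a limit as well. All three therefore share the same standing, which is described by the limit of > 20000 nM in this assay, at which 3 of the 3 values shown sit. The changes among them, furan-3-yl in place of ethynyl, thiophen-2-yl in place of ethynyl and thiophen-2-yl in place of furan-3-yl, give steps a step that the two limits leave unreadable from compound 1 to compound 2, a step that the two limits leave unreadable from compound 1 to compound 3 and a step that the two limits leave unreadable from compound 2 to compound 3 whose size cannot be read.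

Compound 4 `C#Cc1cn([C@@H]2O[C@H](CO)[C@@H](O)[C@H]2O)c2ncnc(SC)c12` differs from compound 1 by methylsulfanyl in place of methyl on an aromatic carbon. Going by the values given here, none of the measured steps touches that position, so nothing measured bears directly on this change; what is known is only that compound 1 and both of its measured relatives sit at the limit in this assay. The expectation for compound 4 is accordingly a step of a number no higher from compound 1 to compound 4 (the limit leaves the size open) that most likely stays at the limit. Compound 4 is estimated at 20000 nM, within 5000 nM to 60000 nM.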

Compound 4, half-maximal inhibitory concentration: 90 nM
Estimate against measurement, compound 4: 220-fold (2.35 log units) above; measured number outside the range, below it.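

The values of compound 1, compound 2 and compound 3 are all limits of the assay rather than numbers, so the steps among them cannot be read, and they showed only that exchanging ethynyl for furan-3-yl or thiophen-2-yl gave no readable number. In this assay, the change at a different place, methylsulfanyl in place of methyl on the aromatic carbon next to the ring nitrogen, gives an at least 220-fold lower number from compound 1 to compound 4 (2.34 log units; beyond the scatter). This position is therefore the first place in the series where a single change yields a readable number, and compound 4 alone stands apart from the rest: the limit of > 20000 nM in this assay, at which 3 of the 4 values shown sit.

The compounds shown leave open whether methylsulfanyl would give a step of this kind with furan-3-yl or thiophen-2-yl in place of ethynyl, as no pair tests that combination. They also leave open how a methoxy group, an amine or a longer chain such as ethylsulfanyl would read at this same position on the core of compound 1, and so whether the sulfur atom itself matters.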